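Trimethoxy pattern on both aryl ends of the chalcone-pyrazoles

The source may report more compounds than this note shows. Statements on the series, on what has been measured and on what is new or still open speak of the compounds shown alone.

Measured so far:
compound 1 `COc1ccc(-c2cc(/C=C/C(=O)c3ccc(OC)c(OC)c3)[nH]n2)cc1` — 24800 nM
compound 2 `COc1cc(-c2cc(/C=C/C(=O)c3ccc(Cl)c(Cl)c3)[nH]n2)cc(OC)c1OC` — > 100000 nM
compound 3 `COc1ccc(-c2cc(/C=C/C(=O)c3cc(OC)c(OC)c(OC)c3)[nH]n2)cc1OC` — 37000 nM

In a functional assay on NCI/ADR-RES cells (Homo sapiens) for inhibition, read by sulforhodamine B assay, with a stated time of 48 h (on this read-out higher numbers stand for weaker inhibition of growth and lower numbers for stronger inhibition of growth), compound 3 gives 37000 nM. Of the two numbers shown, the number for compound 3 is the larger, yet the gap to compound 1 at 24800 nM lies within the usual scatter. For compound 2 this assay reports only a limit, (the limit of > 100000 nM in this assay, at which 1 of the 3 values shown sits), and not a number.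

Compound 4 `COc1cc(C(=O)/C=C/c2cc(-c3cc(OC)c(OC)c(OC)c3)n[nH]2)cc(OC)c1OC` differs from compound 3 by methoxy in place of hydrogen on an aromatic carbon. Within the data shown here, no measured pair isolates this change, so its size is not known from the series. A step within the scatter, or slightly toward weaker inhibition, is expected from compound 3 to compound 4, a 1.2-fold higher number from compound 3 to compound 4 (0.09 log units; within the scatter). Compound 4 is estimated at 45000 nM, between 15000 nM and 100000 nM.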

Compound 4, concentration for total growth inhibition: 21400 nM
For compound 4 the middle estimate is 2.1-fold (0.32 log units) above the measured one; the range from low to high includes it.
By their numbers in this assay, from the lowest: compounds 4, 1 and 3 (each within the scatter of the next). At a limit, above all of these: compound 2.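

Methoxy in place of hydrogen on this aromatic carbon, ortho to a methoxy group, gives a 1.7-fold lower number from compound 3 to compound 4 (0.24 log units; within the scatter), the only step shown between compounds that differ in one place. In this assay this position therefore carries either hydrogen or methoxy with no step beyond the scatter. Nothing measured here gives a cause for this step.

Open, on these data alone, is whether an amine or a carboxylic acid at this position would give a step beyond the scatter. As far as these compounds go, a longer chain, such as ethoxy, is equally open.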